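This account rests on a few compounds, and the source may have more. Where it says the series, first, only, none or still open, it means among the compounds named here.

In an ADME assay on K562 cells (Homo sapiens) for cytotoxicity, with a stated time of 72 h (a higher number here means a weaker inhibitor, a lower number a stronger inhibitor), compound 1 `COc1ccccc1CNc1ncnc2c1ncn2C1CCCCO1` gives 97000 nM and compound 2 `COc1cccc(CNc2ncnc3c2ncn3C2CCCCO2)c1` gives 61000 nM, so compound 2 stands within the scatter of compound 1. Compound 3 `COc1ccc(CNc2ncnc3c2ncn3C2CCCCO2)cc1` carries 4-methoxyphenyl in place of 3-methoxyphenyl on a saturated chain carbon bound to a nitrogen on an aromatic ring. Going by the values given here, the one measured step bearing on this is a 1.6-fold lower number from compound 1 to compound 2 (0.20 log units; within the scatter), a similar exchange of methoxyphenyl groups that stayed within the scatter. No step beyond the scatter is therefore expected in this assay, and the estimated step is a 1.1-fold higher number from compound 2 to compound 3 (0.06 log units; within the scatter). Compound 3 is expected at 70000 nM, with an estimated range of 35000 nM to 130000 nM.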

Compound 3, half-maximal inhibitory concentration: > 100000 nM
Compound 3 ended at the assay's limit (the forecaster's own chance of this, stated with the estimate: 15%); middle value at least 1.4-fold (0.15 log units) away from the limit.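

In this assay compound 3 gives > 100000 nM, which is a limit of the assay and not a number: the limit of > 100000 nM in this assay, at which 1 of the 3 values shown sits. With 4-methoxyphenyl in this place, the result is an at least 1.6-fold higher number from compound 2 to compound 3 (0.21 log units; that floor lies within the scatter), and an at least 1.0-fold higher number from compound 1 to compound 3 (0.01 log units; that floor lies within the scatter). Going by these compounds, all three methoxyphenyl placements have now been read, and these floors show no step beyond the scatter, though the full size of either step is unknown. The compounds shown leave open whether an amine or a carboxylic acid in place of the methoxy group would move the number beyond the scatter. They also leave open what a longer chain at this place would do.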